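This account rests on a few compounds, and the source may have more. Where it says the series, first, only, none or still open, it means among the compounds named here.

Working notes on the series, read in an ADME assay on Huh-7 cells (Homo sapiens) for cytotoxicity, with a stated time of 72 h (a higher number here means that more compound is tolerated, a lower number that less compound is tolerated), for all compounds. Compound 1 `CC(C)CCn1nc(-c2cccs2)c(O)c(C2=NS(=O)(=O)c3cc(NS(=O)(=O)C4CC4)ccc3N2)c1=O` gives > 1000 nM as a limit of the assay. Compound 2 `CCC(C)(C)c1nn(CCC(C)C)c(=O)c(C2=NS(=O)(=O)c3cc(NS(C)(=O)=O)ccc3N2)c1O` gives > 1000 nM as a limit too. Compound 3 `CCC(C)CCn1nc(-c2cccs2)c(O)c(C2=NS(=O)(=O)c3cc(NS(C)(=O)=O)ccc3N2)c1=O` gives > 1000 nM as a limit as well, so no number fixes where it stands. Among the compounds with values here, the series so far is summed up by the limit of > 1000 nM in this assay, at which 3 of the 3 values shown sit, and no pair of measured compounds differs in one place only.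

Compound 4 `CC(C)Cn1nc(-c2cccs2)c(O)c(C2=NS(=O)(=O)c3cc(NS(C)(=O)=O)ccc3N2)c1=O` carries isopropyl in place of 2-methylbutyl on a saturated chain carbon bound to an aromatic nitrogen and otherwise matches compound 3. No step beyond the scatter is expected in this assay for this change, and neither direction is favoured. That expectation rests on compound 3 with its limit > 1000 nM as the only reference. The estimated step is a step that the limit leaves unreadable from compound 3 to compound 4 and it is expected to stay within the scatter. Compound 4 is expected near 2000 nM with an estimated range from 1000 nM to 5000 nM and will probably be reported only as a limit.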

Compound 4, half-maximal cytotoxic concentration: > 1000 nM
Compound 4 ended at the assay's limit; the forecaster's own chance of this, stated with the estimate: 85%; the middle value lies beyond the limit too.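

Compound 3 and compound 4 both sit at a limit of the assay, so no step can be read between them: the limit of > 1000 nM in this assay, at which 4 of the 4 values shown sit. The compounds shown leave open where any of them truly stands in this assay, and whether isopropyl in place of 2-methylbutyl changes the value at all.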